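A Fluorophenyl Thioether in Place of a Dichlorophenoxy Group

The compounds below may be only part of what the source reports. "The series", "measured", "known", "first", "only" and "open" are said of these compounds alone.

Measured so far:
compound 1, `Nc1cc(N)c2nc(-c3ccccc3)c(Oc3ccc(Cl)c(Cl)c3)nc2c1`, in a functional assay on SN12C cells (Homo sapiens) for inhibition, read by sulforhodamine B assay, with a stated time of 48 h (a lower number here means that less compound is tolerated, a higher number that more compound is tolerated), gives < 100000 nM, which is a limit of the assay and not a number.
compound 2, `Nc1cc(N)c2nc(-c3ccccc3)c(NCc3ccc(Cl)c(Cl)c3)nc2c1`, in this assay gives 87100 nM.
compound 3, `CCOC(=O)[C@H](CCC(=O)O)NC(=O)c1ccc(Sc2nc3cc(N)cc(N)c3nc2-c2ccccc2)cc1`, in this assay gives < 100000 nM, again a limit of the assay.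

Compound 1 stands at a limit rather than at a number in this assay; two of the three values sit at that limit (the limit of < 100000 nM in this assay, at which 2 of the 3 values shown sit), and the only number shown, for compound 2, lies close to it. Among the compounds with values here, no pair of measured compounds differs in a single place, so no measured step guides the change considered here.

Compound 4, `Nc1cc(N)c2nc(-c3ccccc3)c(Sc3ccc(F)cc3)nc2c1`, is yet to be measured. It differs from compound 1 in one place: (4-fluorophenyl)sulfanyl in place of 3,4-dichlorophenoxy on an aromatic carbon. The shared core with its phenyl group stays in place. Because compound 1 gives < 100000 nM, and because compound 2 gives 87100 nM in the same weak region, the expected step that the limit leaves unreadable from compound 1 to compound 4 is none beyond the scatter. Compound 4 is therefore expected to give about 70000 nM in this assay, with a range from 25000 nM to 100000 nM, and it may well again return only a limit.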

Compound 4, concentration lethal to 50% of the cells: < 100000 nM
Compound 4 ended at the assay's limit (the forecaster's own chance of this, stated with the estimate: 45%); the middle value is on the limit's open side.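

In this assay compound 4 gives < 100000 nM, a limit of the assay and not a number. The step between compound 1 and compound 4 cannot be read because both stand at a limit: the limit of < 100000 nM in this assay, at which 3 of the 4 values shown sit. The compounds shown leave open whether (4-fluorophenyl)sulfanyl in place of 3,4-dichlorophenoxy changes the result in this assay at all.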